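Swapping the anilide ring: dichlorophenyl to trifluoromethoxyphenyl

The source may report more compounds than this note shows. Statements on the series, on what has been measured and on what is new or still open speak of the compounds shown alone.

These compounds share one core, an aminopyridine carrying an alkyne that links to a methylbenzamide, and differ only in the ring attached to the amide nitrogen. Compound 1 `Cc1ccc(C(=O)Nc2cccc(Cl)c2)cc1C#Cc1cc(-c2cnn(C)c2)cnc1N` carries a 3-chlorophenyl ring on that nitrogen; in an ADME assay on RBL-2H3 cells (Rattus norvegicus) for cytotoxicity, read by CCK-8 assay, with a stated time of 24 h (on this read-out higher numbers stand for lower toxicity in this test and lower numbers for higher toxicity in this test), compound 1 gives 24.8 nM, a low number that marks it as quite toxic to these cells. Compound 2 `Cc1ccc(C(=O)Nc2ccc(Cl)cc2Cl)cc1C#Cc1cc(-c2cnn(C)c2)cnc1N` carries a 2,4-dichlorophenyl ring instead, but in this assay compound 2 gives "not determined" (no result reported), so there is no number to place it on. Compound 3 `Cc1ccc(C(=O)Nc2cccc(OC(F)(F)F)c2)cc1C#Cc1cc(-c2cnn(C)c2)cnc1N` is the next variant, with the change (3-(trifluoromethoxy)phenyl in place of 2,4-dichlorophenyl on an amide-type nitrogen). Among the compounds with values here, no measured pair here separates two compounds by a single change, so no reference step exists for how much such a ring swap moves the read-out. Within the data shown here, the only anchor is compound 1, and the expectation is that compound 3 stays in the same region of toxicity, with the direction of any shift unknown. For compound 3 in this assay the estimate is 25 nM, with a range from 8 nM to 80 nM.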

Compound 3, half-maximal cytotoxic concentration: 33.7 nM
Compound 3: the middle estimate sits 1.3-fold (0.13 log units) below what was measured; measured number inside the range.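

Within the data shown here, compound 3 gives the first readable comparison on the ring attached to the amide nitrogen, because it differs from compound 1 in one place only: trifluoromethoxy stands in place of chloro on an aromatic carbon. In this assay, this swap gives a 1.4-fold higher number from compound 1 to compound 3 (0.13 log units; within the scatter), so the test does not tell the two compounds apart, and the 3-(trifluoromethoxy)phenyl ring keeps the read-out in the same low, toxic region as the 3-chlorophenyl ring. No available measurement speaks to why these two groups read alike, so the result records an outcome and not an explanation.

Compound 2 has no number, so the 2,4-dichlorophenyl ring cannot be placed against the other two, and any step involving it cannot be read. On these data alone, with only chloro and trifluoromethoxy to compare, it remains open whether a very different group on this ring, such as an amine or a carboxylic acid, would move the read-out beyond the usual scatter of this test.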